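Dropping One Chlorine from the Benzyl Group of Compound 1

The source may report more compounds than this note shows. Statements on the series, on what has been measured and on what is new or still open speak of the compounds shown alone.

Going by the values given here, compound 1 `CCCn1c(=O)c2nc(-c3cnn(Cc4cc(Cl)ccc4Cl)c3)[nH]c2n(CCC)c1=O` is the only compound here with a numerical result in an in vitro assay on HEK293 cells for displacement of a labelled ligand from adenosine receptor A2b (Homo sapiens) (a lower number here means a stronger inhibitor, a higher number a weaker inhibitor), where compound 1 gives 29 nM. Compound 2 `CCCn1c(=O)c2nc(-c3cnn(-c4ccccc4)c3C(F)(F)F)[nH]c2n(CCC)c1=O` has only a limit of this assay, with compound 2 reported as > 6600 nM; this matches (the limit of > 6600 nM in this assay, at which 1 of the 2 values shown sits), and it is a boundary rather than a measured number, so compound 2 gives no direct guide to small changes.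

Compound 3 `CCCn1c(=O)c2nc(-c3cnn(Cc4cccc(Cl)c4)c3)[nH]c2n(CCC)c1=O` differs from compound 1 in one place: hydrogen in place of chloro on an aromatic carbon. Among the compounds with values here, no measured pair here shows what removing one such chloro group does, so the size of the step is uncertain. A modest loss of potency is expected, of a size a 2.1-fold higher number from compound 1 to compound 3 (0.32 log units; beyond the scatter), which could still fall within the usual scatter. Compound 3 is therefore estimated at 60 nM, with a plausible range from 20 nM to 200 nM.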

Compound 3, inhibition constant: 18 nM
Beside the measured number, compound 3's estimate is 3.3-fold (0.52 log units) above it, and the stated range ends above it.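

In this assay, going from 2,5-dichlorobenzyl to 3-chlorobenzyl gives a 1.6-fold lower number from compound 1 to compound 3 (0.21 log units; within the scatter) and so amounts to no real change in the number. Going by these compounds alone, this pair therefore shows what no earlier compound could: a low number does not depend on the chloro group at this position, and hydrogen serves as well there. Nothing among the data at hand accounts for this result.

On these data alone, it remains open whether other groups on this same aromatic carbon, such as a methoxy group, an amine or a carboxylic acid, would also leave the number unchanged. As far as these compounds go, it is also open whether the chloro group that stays in compound 3 could be replaced by hydrogen too, which would leave a plain benzyl group.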